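The compounds below may be only part of what the source reports. "The series", "measured", "known", "first", "only" and "open" are said of these compounds alone.

Measured compounds in an ADME assay on CCRF-HSB-2 cells (Homo sapiens) for cytotoxicity, with a stated time of 7 days; a higher number here means that more compound is tolerated, a lower number that less compound is tolerated:
Compound 1 `CN(C)c1nc(N)nc2c1ncn2/C=C1/CC1(CO)CO` gives > 20000 nM, a limit of the assay.
Compound 2 `CCCSc1nc(N)nc2c1ncn2/C=C1/CC1(CO)CO` gives 98000 nM.
Compound 3 `CC(C)Nc1nc(N)nc2c1ncn2/C=C1/CC1(CO)CO` gives > 20000 nM, a limit of the assay.

Compound 1 stands at the limit only, with no number read for it; compound 3 shows the same, so two of the three values sit at the limit (the limit of > 20000 nM in this assay, at which 2 of the 3 values shown sit). Compound 4 `CC(C)Sc1nc(N)nc2c1ncn2/C=C1/CC1(CO)CO` differs from compound 1 by isopropylsulfanyl in place of dimethylamino on an aromatic carbon. The measured steps at this position are a step that the limit leaves unreadable from compound 1 to compound 2 and a step that the two limits leave unreadable from compound 1 to compound 3, both of unreadable size; the limit at compound 1 leaves them so, and a step that the limit leaves unreadable from compound 2 to compound 3 is likewise unreadable. With compound 2 at a readable high value and the others at the limit, little cytotoxicity is expected for compound 4 in this assay, likely another limit or a high number. The estimate for compound 4 is 60000 nM, range 20000 nM to 200000 nM, an expected step that the limit leaves unreadable from compound 1 to compound 4.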

Compound 4, half-maximal cytotoxic concentration: 94000 nM
For compound 4 the middle estimate is 1.6-fold (0.19 log units) below the measured one; low and high end bracket the measured number.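

Within the data shown here, compound 4 gives the first readable step at this position: in this assay, isopropyl in place of propyl on the sulfur gives a 1.0-fold lower number from compound 2 to compound 4 (0.02 log units; within the scatter), so these two sulfur-linked chains are not told apart. The steps from compound 1 and compound 3 to compound 4 cannot be read, since compound 1 and compound 3 each stand at a limit: the limit of > 20000 nM in this assay, at which 2 of the 4 values shown sit.

Going by these compounds, whether a longer chain on the sulfur or a benzyl group there would stay level with these two remains open. So does how far the amino-linked compounds lie from the sulfur-linked ones.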